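A methyl on the chain: cytotoxicity expected for compound 4

A few compounds are considered here, and "the series" means these few. Any claim that something is new, unique, unknown or untested is made for them only; others in the source may bear on it.

Three close relatives of the shared core have been tested in an ADME assay on BHK-21 cells (Mesocricetus auratus) for cytotoxicity, with a stated time of 3 days; a higher number here means that more compound is tolerated, a lower number that less compound is tolerated. Compound 1 `O=C(CCSc1nnc(-c2ccncc2)s1)Nc1ccc(Cl)cc1` gives 8210 nM in this assay. Compound 2 `O=C(CCSc1nnc(-c2ccncc2)s1)Nc1c(Cl)cccc1Cl` gives 10300 nM. For compound 3 `O=C(CCSc1nnc(-c2ccncc2)s1)Nc1ccc(Cl)cc1Cl` this assay reports only a limit, > 50000 nM, and no number. Going by the values given here, of the two numbers, the one for compound 2 is the higher, though only by the step of a 1.3-fold higher number from compound 1 to compound 2 (0.10 log units; within the scatter), which lies within the scatter, so the two compounds cannot be told apart. The steps of an at least 6.0-fold higher number from compound 1 to compound 3 (0.78 log units; beyond the scatter) and an at least 4.8-fold higher number from compound 2 to compound 3 (0.68 log units; beyond the scatter) both reach beyond the scatter, and both lead to the limit (the limit of > 50000 nM in this assay, at which 1 of the 3 values shown sits).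

Compound 4 `CC(CSc1nnc(-c2ccncc2)s1)C(=O)Nc1c(Cl)cccc1Cl` differs from compound 2 in one place: methyl in place of hydrogen on a saturated chain carbon bound to a carbonyl carbon and a saturated chain carbon. All three measured steps change the ring on the amide-type nitrogen and leave the saturated chain untouched, so none of them bears directly on this change. Among the compounds with values here, with no measured step touching the chain, no shift beyond the scatter is expected. The estimated step of a 1.1-fold higher number from compound 2 to compound 4 (0.03 log units; within the scatter) is expected to stay small. Compound 4 is therefore estimated at 11000 nM, with a range from 4000 nM to 35000 nM.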

Compound 4, half-maximal cytotoxic concentration: > 50000 nM
Compound 4 gave a limit, no number (the forecaster's own chance of this, stated with the estimate: 15%); middle value at least 4.5-fold (0.65 log units) away from the limit.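

In this assay, the saturated chain turns out not to be a silent part of the molecule, as one methyl in place of hydrogen on a saturated chain carbon bound to a carbonyl carbon and a saturated chain carbon gives an at least 4.8-fold higher number from compound 2 to compound 4 (0.68 log units; beyond the scatter). Until now, only changes to the ring on the amide-type nitrogen had moved this read-out beyond the scatter, whereas here the 2,6-dichlorophenyl ring stays as it is and a change of a single heavy atom on the chain is enough. The result for compound 4 is a limit, so the step gives a floor for the change and not its full size: the limit of > 50000 nM in this assay, at which 2 of the 4 values shown sit.

The compounds shown leave open whether an ethyl, a hydroxyl or an amine on this same chain carbon would shift the read-out in the same way as the methyl, or whether the shift is particular to the methyl. They also leave open whether the same methyl would produce a comparable step in compound 1, since among the compounds shown only compound 4 carries it.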